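This account rests on a few compounds, and the source may have more. Where it says the series, first, only, none or still open, it means among the compounds named here.

Compound 1 `COc1ccc(N(CC(=O)NCCC[Se]c2ccccc2)C(=O)c2ccccc2)cc1`: in a functional assay on MCF7 cells (Homo sapiens) for cytotoxicity, read by MTT assay, with a stated time of 24 h (a higher number here means a weaker inhibitor, a lower number a stronger inhibitor), compound 1 stops at the limit >= 100000 nM.
Compound 2 `COc1ccc(N(CC(=O)NCCC[Se]c2ccccc2)C(=O)/C=C/c2ccccc2)cc1`: in this assay compound 2 stops at the limit >= 100000 nM.
Compound 3 `COc1ccc(N(CC(=O)NCCC[Te]c2ccccc2)C(=O)c2ccccc2)cc1`: in this assay compound 3 gives 27000 nM.

Compound 3 differs from compound 1 by a group of 7 heavy atoms (6 carbon, 1 tellurium; one six-membered aromatic ring of carbon only) in place of a group of 7 heavy atoms (6 carbon, 1 selenium; one six-membered aromatic ring of carbon only), on a saturated chain carbon, three bonds along the chain from an amide-type nitrogen. For the measured compounds named here, that change gives an at least 3.7-fold lower number from compound 1 to compound 3 (0.56 log units; beyond the scatter), and compound 3 holds the only number among the three measured compounds. Compound 2 differs from compound 1 by 2-phenylethenyl in place of phenyl on a carbonyl carbon. The step reads a step that the two limits leave unreadable from compound 1 to compound 2 because the limit of >= 100000 nM in this assay, at which 2 of the 3 values shown sit, holds both of those values, so the size of that change cannot be read from compound 1 and compound 2.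

Compound 4 `COc1ccc(N(CC(=O)NCCC[Te]c2ccccc2)C(=O)/C=C/c2ccccc2)cc1` has not yet been measured. It differs from compound 3 by 2-phenylethenyl in place of phenyl on a carbonyl carbon, the same change as that from compound 1 to compound 2, made at the same place. Since the earlier instance of this change gave no readable step, the expectation for compound 4 rests on compound 3 and its value of 27000 nM, with a step of a 1.1-fold lower number from compound 3 to compound 4 (0.03 log units; within the scatter) expected and left open in either direction. Compound 4 is thus expected to give about 25000 nM in this assay, estimated to fall between 8000 nM and 90000 nM.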

Compound 4, half-maximal inhibitory concentration: 2000 nM
Beside the measured number, compound 4's estimate is 13-fold (1.10 log units) above it; the measured number lies below the stated range.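

In this assay, 2-phenylethenyl in place of phenyl gives a 14-fold lower number from compound 3 to compound 4 (1.13 log units; beyond the scatter), and tellurium in place of selenium on the 2-phenylethenyl core gives an at least 50-fold lower number from compound 2 to compound 4 (1.69 log units; beyond the scatter). For the compounds shown here, the exchange of selenium for tellurium lowers the number on both cores, but whether its size differs between them stays unsettled: the same change on two cores in this assay, an at least 3.7-fold lower number (0.56 log units; beyond the scatter) from compound 1 to compound 3 and an at least 50-fold lower number (1.69 log units; beyond the scatter) from compound 2 to compound 4; the limit leaves it open whether they differ The 2-phenylethenyl change has only one readable instance, on the tellurium compounds, and its step on the selenium compounds cannot be read, so these data do not show that it carries from one core to the other.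

The compounds shown leave open whether the double bond itself matters, which a saturated 2-phenylethyl group in place of 2-phenylethenyl would test. They also leave open how the tellurium compounds would respond to a longer chain on the tellurium, or to sulfur in place of the heavier atom.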